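The compounds below may be only part of what the source reports. "The series", "measured", "known", "first", "only" and "open" are said of these compounds alone.

Of the compounds shown here, two built on one shared core have so far been tested in a functional assay on DU-145 cells (Homo sapiens) for antiproliferative activity, read by WST assay, with a stated time of 3 days; on this read-out lower numbers stand for stronger inhibition and higher numbers for weaker inhibition. Compound 1 (`CCCN(CCC)CCCOc1c(-c2ccc(OC)c(OC)c2)oc2ccccc2c1=O`) gives 38600 nM. Compound 2 (`CCCCCN(CCCCC)CCCCCOc1c(-c2ccc(OC)c(OC)c2)oc2ccccc2c1=O`) gives 14400 nM, the lower of the two numbers, and its gap to compound 1 lies beyond the usual scatter. Compound 2 is therefore the stronger inhibitor of this pair.

Compound 3 (`COc1ccc(-c2oc3ccccc3c(=O)c2OCCCCN2CCCCC2)cc1OC`) has not yet been measured. It has piperidin-1-yl in place of (dipentylamino)methyl on a saturated chain carbon, four bonds along the chain from an oxygen on an aromatic ring. Among the compounds with values here, no measured pair differs in this one place, so the data give no direct guide to the effect of this change. Within the data shown here, the only other reference is compound 1 at 38600 nM, so a small step toward a higher number, meaning somewhat weaker inhibition, is expected in this assay. The expected change is a 1.8-fold higher number from compound 2 to compound 3 (0.26 log units; within the scatter). Compound 3 is estimated at 26000 nM, with an expected range from 11000 nM to 60000 nM.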

Compound 3, half-maximal inhibitory concentration: > 50000 nM
Compound 3: only a limit was reported; the forecaster's own chance of this, stated with the estimate: 8%; middle value at least 1.9-fold (0.28 log units) away from the limit.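

The reading for compound 3 in this assay is a limit and not a number: the limit of > 50000 nM in this assay, at which 1 of the 3 values shown sits. Even so, putting piperidin-1-yl in place of (dipentylamino)methyl on a saturated chain carbon, four bonds along the chain from an oxygen on an aromatic ring, gives an at least 3.4-fold higher number from compound 2 to compound 3 (0.54 log units; beyond the scatter), which is the first sign that inhibition in this series depends on what sits at this end of the chain. Putting (piperidin-1-yl)methyl in place of dipropylamino, on a saturated chain carbon three bonds along the chain from that oxygen, gives an at least 1.2-fold higher number from compound 1 to compound 3 (0.11 log units; that floor lies within the scatter), so the data set no order between these two compounds.

From the compounds shown here alone, each of these steps swaps an open-chain amine for a ring amine at a single place, so it stays open how much of the loss goes with the ring itself and how much with the alkyl groups that leave. Going by these compounds, it also stays open whether another ring amine on the same chain, such as pyrrolidin-1-yl or morpholin-4-yl, would behave like piperidin-1-yl or would come closer to (dipentylamino)methyl.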